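Solubility series: aryl and alkyl substituents on the shared core

The compounds below may be only part of what the source reports. "The series", "measured", "known", "first", "only" and "open" are said of these compounds alone.

Measured so far in a physicochemical assay for solubility, with a stated time of 18 h, at pH 7.4; on this read-out lower numbers stand for lower solubility and higher numbers for higher solubility:
compound 1 `COc1ccc(F)cc1CNCCCNc1ccnc2cc(Cc3ccc(C#N)cc3)ccc12` gives 4200 nM
compound 2 `FC(F)(F)c1ccc(-c2ccc3c(NCCCNCc4ccco4)ccnc3c2)cc1` gives 32000 nM
compound 3 `CCC(CC)c1ccc2c(NCCCNCc3ccco3)ccnc2c1` gives 4200 nM

Compound 1 stands level with compound 3 at the digits shown, the two together the lowest numbers of the three, while compound 2 sits highest.

Compound 4 `COc1ccc(-c2ccc3c(NCCCNCc4cc(F)ccc4OC)ccnc3c2)cc1` is not yet measured. Relative to compound 1 the change is 4-methoxyphenyl in place of 4-cyanobenzyl on an aromatic carbon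

Among the measured compounds shown here, the one step between measured compounds that touches this position is a 7.6-fold lower number from compound 2 to compound 3 (0.88 log units; beyond the scatter). There an aryl group directly on the core went with the higher number, and compound 4 also carries an aryl group at that place, but with a different amine side chain, so the bearing is loose. A modest rise is expected, with wide uncertainty: compound 4 is estimated at 7000 nM (range 1800 nM to 28000 nM), meaning a 1.7-fold higher number from compound 1 to compound 4 (0.22 log units; within the scatter).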

Compound 4, solubility: 32000 nM
Beside the measured number, compound 4's estimate is 4.6-fold (0.66 log units) below it; measured number outside the range, above it.
By their numbers in this assay, from the lowest: compounds 1 and 3 (each within the scatter of the next); then compounds 2 and 4 (each within the scatter of the next).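

Replacing 4-cyanobenzyl with 4-methoxyphenyl gives a 7.6-fold higher number from compound 1 to compound 4 (0.88 log units; beyond the scatter) in this assay. This shows that the position still responds with the amine side chain of compound 1, and the direction matches a 7.6-fold lower number from compound 2 to compound 3 (0.88 log units; beyond the scatter), where the aryl group directly on the core also carries the higher number. No measurement here bears on the reason for the rise. The step changes the ring substituent and the attachment to the core together, so their shares remain unresolved. Also open, on these data alone, is how an unsubstituted phenyl or a phenyl bearing a carboxylic acid would read at this place.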